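Bromo for Fluoro on the Aryl Nitrile Arm

The source may report more compounds than this note shows. Statements on the series, on what has been measured and on what is new or still open speak of the compounds shown alone.

Compound 1 `Cc1ccc2ccc(-c3cccc(OC(F)(F)F)c3)cc2n1` returns only a limit in a functional assay on CHO cells for inhibition of metabotropic glutamate receptor 5 (Rattus norvegicus), read by FLIPR and calcium flux; a higher number here means a weaker inhibitor, a lower number a stronger inhibitor: > 10000 nM, which is the limit of > 10000 nM in this assay, at which 1 of the 2 values shown sits. Among the measured compounds shown here, compound 2 `Cc1ccc2ccc(-c3cc(F)cc(C#N)c3)cc2n1` gives the single number in this assay, 0.8 nM. Compound 3 `Cc1ccc2ccc(-c3cc(Br)cc(C#N)c3)cc2n1` differs from compound 2 by bromo in place of fluoro on an aromatic carbon. No step between measured compounds is available to size this change, so from the numbers shown only a small shift in this assay, within or little beyond the scatter, is expected. The estimate for compound 3 in this assay is 1.5 nM, with a range of 0.4 nM to 6 nM. The step expected, a 1.9-fold higher number from compound 2 to compound 3 (0.27 log units; within the scatter), is accordingly small.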

Compound 3, half-maximal inhibitory concentration: 13 nM
Beside the measured number, compound 3's estimate is 8.7-fold (0.94 log units) below it, outside the stated range (above it).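

In this assay, among the compounds shown here, this position proves sensitive to the choice of halogen: the change meta to a cyano group gives a 16-fold higher number from compound 2 to compound 3 (1.21 log units; beyond the scatter), the first sized step. Compound 3 still returns a number rather than a limit, so bromo here costs potency without removing measurable inhibition. Nothing shown bears on the cause of this step.

Open, from the compounds shown here alone, is whether chloro or methoxy at this place would fall nearer to compound 2 or to compound 3. Also open, going by these compounds, is how an amide in place of the nitrile would read with either halogen kept.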